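The source may hold more compounds than are shown below. What is called first, only, known or untested is meant among the compounds shown, and "the series" means these compounds.

Measured in a functional assay on MIA PaCa-2 cells (Homo sapiens) for inhibition, read by MTT assay, with a stated time of 4 days; on this read-out higher numbers stand for weaker inhibition and lower numbers for stronger inhibition:
- compound 1 `COc1cc(NC(C)CCCNC(=O)NN)c2ncccc2c1`: >= 250000 nM (a limit)
- compound 2 `CCOC(=O)NC(c1ccccc1)c1ccc(Cl)cc1`: 142000 nM
- compound 3 `COc1cc(NC(C)CCCNC(=O)NNC(=O)N(C)C(c2ccccc2)c2ccccc2)c2ncccc2c1`: 18000 nM

Compound 1 gives >= 250000 nM in this assay, and this is a limit of the assay, not a number. The starting point for the step is therefore only (the limit of >= 250000 nM in this assay, at which 1 of the 3 values shown sits).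

The compound to be measured next, compound 4 `COc1cc(NC(C)CCCNC(=O)NNC(=O)NCCCO)c2ncccc2c1`, keeps the core of compound 1. The change is (3-hydroxypropyl)carbamoyl in place of hydrogen on an amine nitrogen.

Going by the values given here, no measured step isolates this change, so the expectation rests on the values alone. Among the compounds with values here, the only true numbers are those of compound 2 at 142000 nM and compound 3 at 18000 nM, and the second of these shows the stronger inhibition. A move toward stronger inhibition, beyond the usual scatter, is expected, with the result most likely falling within the span set by these two compounds. The estimated change is an at least 5.5-fold lower number from compound 1 to compound 4 (0.74 log units; beyond the scatter), and its size remains uncertain while compound 1 has only a limit. For compound 4 the expected value is 45000 nM, with an estimated range of 12000 nM to 170000 nM.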

Compound 4, half-maximal inhibitory concentration: >= 250000 nM
Compound 4 was reported as a limit; the forecaster's own chance of this, stated with the estimate: 20%; at least 5.5-fold (0.74 log units) between middle value and limit.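

In this assay compound 4 gives >= 250000 nM, a limit and not a number. Compound 1 gives >= 250000 nM, also a limit. No step can be read between compound 1 and compound 4. On these data alone, whether (3-hydroxypropyl)carbamoyl in place of hydrogen on an amine nitrogen changes inhibition at all, and by how much, stays open.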